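Swapping Methoxy for Chloro on the Amide Phenyl Ring

The source may report more compounds than this note shows. Statements on the series, on what has been measured and on what is new or still open speak of the compounds shown alone.

Of the compounds shown here, three sharing one core have been measured in an assay on CHO cells for displacement of a labelled ligand from adenosine receptor A3 (Homo sapiens), tested at 1 uM; on this read-out higher numbers stand for more inhibition at the one concentration tested (going by the name of the read-out) and lower numbers for less inhibition. Compound 1 (`CC(=O)Nc1nn(-c2ccccc2)c(=O)c2ccccc12`) gives 0% in this assay. Compound 2 (`O=C(Nc1ccccc1Cl)Nc1nn(-c2ccccc2)c(=O)c2ccccc12`) gives 49%, and compound 3 (`COc1ccc(C(=O)Nc2nn(-c3ccccc3)c(=O)c3ccccc23)cc1`) gives 10%. On these numbers compound 3 stands second highest of the three: its nearest neighbour is compound 1, at a difference within the scatter, and its furthest is compound 2. The step of a number 10 percentage points higher from compound 1 to compound 3 (within the scatter) lies within the scatter, while the step of a number 39 percentage points lower from compound 2 to compound 3 (beyond the scatter) lies beyond it.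

Compound 4 (`O=C(Nc1nn(-c2ccccc2)c(=O)c2ccccc12)c1ccc(Cl)cc1`) has not yet been measured. It differs from compound 3 in one place: chloro in place of methoxy on an aromatic carbon. Among the compounds with values here, none of the measured steps touches this part of the molecule; the steps of a number 49 percentage points higher from compound 1 to compound 2 (beyond the scatter) and a number 10 percentage points higher from compound 1 to compound 3 (within the scatter) replace the whole group on the carbonyl carbon, and they show only that an aromatic amide like compound 3 gives a number close to compound 1. Within the data shown here, no measured step therefore bears directly on this change, and a step no larger than the scatter is expected in this assay, in no particular direction. Compound 4 is estimated at 15%, with a range from 0% to 40%, which means an expected step of a number 5 percentage points higher from compound 3 to compound 4 (within the scatter).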

Compound 4, a percentage reported as inhibition, at one concentration (the size of the read-out at that concentration, not a potency): 17%
Compound 4: middle estimate off by 2 percentage points, on the low side, and the stated range covers the measured number.
By their numbers in this assay, from the lowest: compounds 1, 3 and 4 (each within the scatter of the next, the first and the last beyond it); then compound 2.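

In this assay, within the data shown here, this is the first direct look at the aromatic carbon para to a large group, and chloro in place of methoxy there gives a number 7 percentage points higher from compound 3 to compound 4 (within the scatter) and so does not clearly separate the two compounds. Against the small methyl group the picture shifts slightly: 4-chlorophenyl in place of methyl on the carbonyl carbon gives a number 17 percentage points higher from compound 1 to compound 4 (beyond the scatter) while the 4-methoxyphenyl step from the same compound stayed within the scatter, yet compound 3 and compound 4 themselves cannot be told apart, so this is a weak hint at most, and the change of whole group on the carbonyl carbon still counts for far more, as 4-chlorophenyl in place of (2-chlorophenyl)amino gives a number 32 percentage points lower from compound 2 to compound 4 (beyond the scatter) and leaves compound 2 the highest of the four. Nothing in the data given explains any of these numbers.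

On these data alone, whether an amine, a carboxylic acid or a longer chain such as ethoxy on this aromatic carbon would stand apart from methoxy and chloro remains open. Also open, as far as these compounds go, is what a (4-chlorophenyl)amino group on the carbonyl carbon would give, which would set the amino link apart from the place of the chloro.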